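Aminomethyl in place of carboxy: expected toxicity read-out

The source may hold more compounds than are shown below. What is called first, only, known or untested is meant among the compounds shown, and "the series" means these compounds.

- compound 1 `COc1cccc2c1nc(-c1c(F)cccc1F)n2Cc1c(F)cccc1F` gives 44.3 uM
- compound 2 `Fc1cccc(F)c1Cn1c(-c2c(F)cccc2F)nc2c(Cl)cccc21` gives 30.4 uM
- compound 3 `O=C(O)c1cccc2c1nc(-c1c(F)cccc1F)n2Cc1c(F)cccc1F` gives 23.5 uM

All three values come from a toxicity assay on CCRF-CEM cells (Homo sapiens) for cytotoxicity (on this read-out higher numbers stand for lower toxicity in this test and lower numbers for higher toxicity in this test), and form a tight group. In this assay compound 3 stands at 23.5 uM and cannot be separated from the other two compounds.

The change under consideration leads to compound 4 (`NCc1cccc2c1nc(-c1c(F)cccc1F)n2Cc1c(F)cccc1F`) and is aminomethyl in place of carboxy on an aromatic carbon with aminomethyl in place of carboxy on an aromatic carbon. Within the data shown here, three measured steps bear on it, all swaps on that same aromatic carbon. They are a 1.5-fold lower number from compound 1 to compound 2 (0.16 log units; within the scatter) and a 1.9-fold lower number from compound 1 to compound 3 (0.28 log units; within the scatter) and a 1.3-fold lower number from compound 2 to compound 3 (0.11 log units; within the scatter) and each of them is small. Methoxy, chloro and carboxy have so far made no difference beyond the scatter, so the series gives no reason to expect a large move here. Among the measured compounds shown here, no aminomethyl compound has been measured yet, which leaves this expectation resting on other groups and calls for a wide range.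

The expected step is a 1.1-fold higher number from compound 3 to compound 4 (0.03 log units; within the scatter) and no change beyond the scatter is expected. In this assay the estimate for compound 4 is 25 uM with an expected range of 11 uM to 50 uM until the measurement is available.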

Compound 4, half-maximal toxic concentration: 49.3 uM
Compound 4: middle estimate off by 2.0-fold (0.29 log units), on the low side; measured number inside the range.
By their numbers in this assay, from the lowest: compounds 3, 2, 1 and 4 (each within the scatter of the next, the first and the last beyond it).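

In this assay, among these compounds, aminomethyl in place of carboxy gives the first step on this aromatic carbon that lies beyond the scatter (a 2.1-fold higher number from compound 3 to compound 4 (0.32 log units; beyond the scatter)), although it is modest and the two groups match in their computed hydrogen-bond donor and acceptor counts and in having no net charge. Aminomethyl stays within the scatter of the other two groups (a 1.6-fold higher number from compound 2 to compound 4 (0.21 log units; within the scatter)) and (a 1.1-fold higher number from compound 1 to compound 4 (0.05 log units; within the scatter)), so the only separation among the steps from these three compounds to compound 4 is the one from carboxy, and methoxy, chloro and aminomethyl cannot be ordered. The compounds shown offer no measurement that explains this separation.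

Open, going by these compounds, is whether the separation from carboxy depends on the nitrogen of aminomethyl, which a hydroxymethyl group on the same carbon would test. A dimethylaminomethyl group or a longer aminoethyl chain would show whether this position stays this flat in this assay once the group grows or the amine is substituted, and a primary amide would give a further comparison with carboxy.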